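Removing a Trifluoromethoxy Group from Compound 2

A few compounds are considered here, and "the series" means these few. Any claim that something is new, unique, unknown or untested is made for them only; others in the source may bear on it.

The two measured compounds share one core. Compound 1 `CC1CCN(c2nc(Cl)nc3c2ncn3Cc2ccc(/C=C/C(=O)Nc3ccccc3N)cc2)CC1` carries a 4-methylpiperidin-1-yl group on it, and compound 2 `Nc1ccccc1NC(=O)/C=C/c1ccc(Cn2cnc3c(Nc4cccc(OC(F)(F)F)c4)nc(Cl)nc32)cc1` carries a (3-(trifluoromethoxy)phenyl)amino group in its place. In a functional assay on HepG2 cells (Homo sapiens) for antiproliferative activity, read by CCK-8 assay, with a stated time of 72 h, tested at 2 uM (a lower number here means a weaker effect, a higher number a stronger effect of the compound at the concentration tested), compound 1 gives 8.73%, and compound 2 gives 16.2%. Among the compounds with values here, the single step between them, a number 7.5 percentage points higher from compound 1 to compound 2 (within the scatter), is the only measured step in this set, and it lies within the scatter, so compound 2 stands at the higher of two numbers that cannot be told apart.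

Within the data shown here, compound 3 `Nc1ccccc1NC(=O)/C=C/c1ccc(Cn2cnc3c(Nc4ccccc4)nc(Cl)nc32)cc1` differs from compound 2 by one change: hydrogen in place of trifluoromethoxy on an aromatic carbon No measured step concerns this change; the one step available, from compound 1 to compound 2, swaps a whole group on a different carbon and is itself within the scatter. Nothing in the data therefore points to a step in this assay beyond the scatter in either direction. Compound 3 is accordingly expected to give a number near that of compound 2, estimated at 13% with a range of 3% to 26%. The expected step, a number 3.2 percentage points lower from compound 2 to compound 3 (within the scatter), is meant as no change beyond the scatter.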

Compound 3, a percentage reported as inhibition, at one concentration (the size of the read-out at that concentration, not a potency): 16.4%
Compound 3: middle estimate off by 3.4 percentage points, on the low side; low and high end bracket the measured number.
By their numbers in this assay, from the lowest: compounds 1, 2 and 3 (each within the scatter of the next).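

In this assay, within the data shown here, the step of a number 0.2 percentage points higher from compound 2 to compound 3 (within the scatter) is the first reading at this place on the phenyl ring itself, since the earlier step swapped the whole group on the shared core. Taking away trifluoromethoxy, with its 5 heavy atoms, meta to a large group, leaves a bare phenyl ring and moves the number by no more than the scatter. The step of a number 7.7 percentage points higher from compound 1 to compound 3 (within the scatter) adds that anilino, like (3-(trifluoromethoxy)phenyl)amino, cannot be told apart from 4-methylpiperidin-1-yl in this assay, so none of the three compounds separates from the others, and no information is available that could account for this result.

What the compounds shown leave open is whether a different group at the same place on the phenyl ring, such as a methoxy group, an amine or a carboxylic acid, would give a number beyond the scatter of that of compound 3. As far as these compounds go, it is also open how these compounds compare in potency, since each reading gives the size of the effect at one concentration only.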